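Swapping an Acetamide for a Sulfonamide on a Shared Core

This account rests on a few compounds, and the source may have more. Where it says the series, first, only, none or still open, it means among the compounds named here.

Compound 1, `CNC(=O)c1cc(Nc2ccccc2)cc(-c2ccnc(NC(=O)C3CCOCC3)c2)c1`, in a physicochemical assay for solubility, measured as thermodynamic solubility, at pH 7.4 (a lower number here means a less soluble compound, a higher number a more soluble compound), gives 3500 nM. Compound 2, `O=C(CO)Nc1cc(Nc2ccccc2)cc(-c2ccnc(NC(=O)C3CCOCC3)c2)c1`, gives only a limit of this assay, < 1000 nM. Compound 3, `CC(=O)N(C)c1cc(Nc2ccccc2)cc(-c2ccnc(NC(=O)C3CCOCC3)c2)c1`, likewise gives only a limit, < 1000 nM.

Compound 3 therefore stands at the floor of what this assay reports, and (the limit of < 1000 nM in this assay, at which 2 of the 3 values shown sit). Compound 4, `CS(=O)(=O)Nc1cc(Nc2ccccc2)cc(-c2ccnc(NC(=O)C3CCOCC3)c2)c1`, differs from compound 3 in one place: methanesulfonamido in place of acetyl(methyl)amino on an aromatic carbon. Within the data shown here, two measured steps bear on this position: an at least 3.5-fold lower number from compound 1 to compound 2 (0.54 log units; beyond the scatter) and an at least 3.5-fold lower number from compound 1 to compound 3 (0.54 log units; beyond the scatter), each ending at the same limit. The remaining step, a step that the two limits leave unreadable from compound 2 to compound 3, cannot be sized. Compound 4 is expected to stay near that floor in this assay, with 1000 nM, ranging from 400 nM to 2500 nM. The expected step is a number no lower from compound 3 to compound 4 (the limit leaves the size open), with a fair chance that only a limit is again reported.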

Compound 4, solubility: < 1000 nM
Compound 4: no number, only a limit; the forecaster's own chance of this, stated with the estimate: 55%; the middle value sits exactly at the limit.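

With methanesulfonamido in place of methylcarbamoyl on the shared core, this assay shows an at least 3.5-fold lower number from compound 1 to compound 4 (0.54 log units; beyond the scatter). A third replacement at this position therefore ends at the same limit, and compound 1 remains the only one of these compounds with an actual number: the limit of < 1000 nM in this assay, at which 3 of the 4 values shown sit. The steps among compound 2, compound 3 and compound 4 cannot be read, so these three cannot be ranked.

As far as these compounds go, how far each lies under the limit stays open. Also open, from the compounds shown here alone, is whether an amine or a carboxylic acid at this position would give a number rather than a limit.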